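Stability series on a fused bicyclic lactam core: aminomethyl analogue

This account rests on a few compounds, and the source may have more. Where it says the series, first, only, none or still open, it means among the compounds named here.

Measured so far:
compound 1 `C[C@@H](O)[C@H]1C(=O)N2C(C(=O)O)=C(C(C)(C)C)O[C@H]12` — 8.1 h
compound 2 `CC(C)(C)C1=C(C(=O)O)N2C(=O)[C@H]([C@H](O)c3ccccc3)[C@H]2O1` — 7 h
compound 3 `CC(C)(C)C1=C(C(=O)O)N2C(=O)[C@H]([C@H](O)CCc3ccccc3)[C@H]2O1` — 21 h

In an ADME assay, in phosphate buffer, at 28 degrees C, at pH 7.0 (on this read-out higher numbers stand for a longer-lived compound and lower numbers for a shorter-lived compound), compound 1 gives 8.1 h, the second highest of the three numbers. Its nearest neighbour is compound 2, the step of a 1.2-fold lower number from compound 1 to compound 2 (0.06 log units; within the scatter) being within the scatter. Compound 3 stands furthest away: a 2.6-fold higher number from compound 1 to compound 3 (0.41 log units; beyond the scatter). The remaining measured step, a 3.0-fold higher number from compound 2 to compound 3 (0.48 log units; beyond the scatter), is of similar size.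

Compound 4 `CC(C)(C)C1=C(C(=O)O)N2C(=O)[C@H](CN)[C@H]2O1` is the next candidate. It differs from compound 1 as follows: aminomethyl in place of 1-hydroxyethyl on a saturated ring carbon. Among the compounds with values here, none of the measured steps touches this change; all three concern the chain bound to the oxygen, whereas here the group on the ring carbon itself is exchanged and the hydroxyl leaves. The measured steps therefore give no direction, only a sense of scale: one step sat within the scatter and two were modest.

For compound 4 a half-life of 6 h is estimated, with a range from 2.5 h to 14 h, the expected step of a 1.4-fold lower number from compound 1 to compound 4 (0.13 log units; within the scatter) being a guess anchored on compound 1 with 8.1 h and held wide for lack of a bearing step.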

Compound 4, half-life: 1.2 h
Compound 4: the middle estimate sits 5.0-fold (0.70 log units) above what was measured, and the stated range ends above it.
By their numbers in this assay, from the lowest: compound 4; then compounds 2 and 1 (each within the scatter of the next); then compound 3.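

In this assay, exchanging the whole group on the saturated ring carbon has a clear effect, with a 6.8-fold lower number from compound 1 to compound 4 (0.83 log units; beyond the scatter). Within the data shown here, this is the first step beyond the scatter towards a lower number: the only earlier downward step, a 1.2-fold lower number from compound 1 to compound 2 (0.06 log units; within the scatter), stayed within it, and the two earlier steps beyond it both went upward. Nothing measured on hand explains the drop.

The change swaps oxygen for nitrogen, shortens the group from 3 heavy atoms to 2 and removes a defined stereocentre, and the compounds shown do not separate these three differences. Hydroxymethyl on the same ring carbon would test the exchange of nitrogen for oxygen at the shorter length, while 1-aminoethyl would test it at the original length.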